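The source may hold more compounds than are shown below. What is called first, only, known or untested is meant among the compounds shown, and "the series" means these compounds.

The series shares a core carrying an ethyl ester and two phenyl rings, and differs only in the group attached through the saturated carbon. For the measured compounds named here, compound 1 `CCOC(=O)c1c(-c2ccccc2)nn(-c2ccccc2)c1Cn1c(S)nc2ccccc21` gives 40 ug/mL in an assay for inhibition of Alpha amylase (Homo sapiens), with a stated time of 30 min (a higher number here means a weaker inhibitor, a lower number a stronger inhibitor), and compound 2 `CCOC(=O)c1c(-c2ccccc2)nn(-c2ccccc2)c1Cn1cnc2ccccc21` gives 35 ug/mL in the same assay; the single measured step, a 1.1-fold lower number from compound 1 to compound 2 (0.06 log units; within the scatter), stays within the scatter. Compound 3 `CCOC(=O)c1c(-c2ccccc2)nn(-c2ccccc2)c1COc1cc(OC)c(C=O)c(OC)c1` gives 40 ug/mL in this assay, level with compound 1 at the digits shown and together with it the highest of the three numbers, with compound 2 furthest from it yet still within the scatter.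

Compound 4 `CCOC(=O)c1c(-c2ccccc2)nn(-c2ccccc2)c1COc1ccc(C=O)cc1` has not yet been measured. It differs from compound 3 in that (a group of 8 heavy atoms (7 carbon, 1 oxygen; one six-membered aromatic ring of carbon only) in place of a group of 12 heavy atoms (9 carbon, 3 oxygen; one six-membered aromatic ring of carbon only), on an oxygen on a saturated carbon), a 4-formylphenyl entering on an oxygen on a saturated carbon. Going by the values given here, no measured step touches this part of the molecule; the only step on record, a 1.1-fold lower number from compound 1 to compound 2 (0.06 log units; within the scatter), sits elsewhere and is within the scatter, and all three measured numbers lie within the scatter of one another. Compound 4 is therefore expected to give 40 ug/mL in this assay, between 20 ug/mL and 80 ug/mL, a step of no change at the digits printed from compound 3 to compound 4 (within the scatter) that is estimated to stay within the scatter.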

Compound 4, half-maximal inhibitory concentration: 60 ug/mL
The estimate for compound 4 lay 1.5-fold (0.18 log units) below the measured number; low and high end bracket the measured number.
By their numbers in this assay, from the lowest: compounds 2, 1, 3 and 4 (each within the scatter of the next).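

In this assay the change on the oxygen on a saturated carbon, with 4-formylphenyl entering for the group of 12 heavy atoms, gives a 1.5-fold higher number from compound 3 to compound 4 (0.18 log units; within the scatter) and so leaves the reading within the scatter at this position. Exchanging the whole group on the saturated chain carbon does no more, with 4-formylphenoxy in place of 1H-benzimidazol-1-yl giving a 1.7-fold higher number from compound 2 to compound 4 (0.23 log units; within the scatter) and the same group in place of the sulfur-bearing group of compound 1 giving a 1.5-fold higher number from compound 1 to compound 4 (0.18 log units; within the scatter) in this series. No measurement available here accounts for these readings. On these data alone, whether an amine or a carboxylic acid in place of the formyl group would carry the number beyond the scatter remains open. So does the part played by the ethyl ester and the two phenyl rings of the shared core, which stay the same in all four compounds.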